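Unsaturation in the Acyl Chain of Compound 1

The source may report more compounds than this note shows. Statements on the series, on what has been measured and on what is new or still open speak of the compounds shown alone.

Among the measured compounds shown here, compound 1 `CC(C)CCC(=O)Nc1ccn([C@H]2CC[C@H](O)[C@@H](C)O2)c(=O)n1` shares its acyl group with compound 2 `CC(C)CCC(=O)Nc1ccn([C@H]2CC[C@H](O[C@H]3O[C@H](C)[C@@H](N(C)C)[C@H](O)[C@H]3O)[C@@H](C)O2)c(=O)n1` but differs from compound 2 in more than one place, so no single step between them is counted. In a functional assay on HCT-116 cells (Homo sapiens) for cytotoxicity, read by sulforhodamine B assay, with a stated time of 24 h (a lower number here means a stronger inhibitor, a higher number a weaker inhibitor), compound 1 gives only a limit, > 20000 nM, and no number is known for it. Compound 2 gives 390 nM in this assay, and compound 3 `CC(C)CC(=O)Nc1ccn([C@H]2CC[C@H](O[C@H]3O[C@H](C)[C@@H](N(C)C)[C@H](O)[C@H]3O)[C@@H](C)O2)c(=O)n1` gives 2140 nM. For the measured compounds named here, the single measured step, a 5.5-fold higher number from compound 2 to compound 3 (0.74 log units; beyond the scatter), shortens the acyl chain on a different core and does not bear directly on the change at hand. Compound 4 `CC(C)=CCC(=O)Nc1ccn([C@H]2CC[C@H](O)[C@@H](C)O2)c(=O)n1` differs from compound 1 by 2-methylprop-1-en-1-yl in place of isobutyl on a saturated chain carbon bound to a carbonyl carbon. Going by the values given here, no measured step introduces a double bond in this chain, and none touches the core of compound 1, whose value sits at the limit of > 20000 nM in this assay, at which 1 of the 3 values shown sits. With compound 1 offering no number to step from, compound 4 is expected to stay near that limit. The expected step of a number no higher from compound 1 to compound 4 (the limit leaves the size open) is therefore none beyond the scatter, and compound 4 is estimated at 20000 nM, within 8000 nM to 60000 nM.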

Compound 4, half-maximal inhibitory concentration: > 20000 nM
Compound 4 was reported as a limit; the forecaster's own chance of this, stated with the estimate: 80%; the middle value lies on the limit itself.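

Compound 1 and compound 4 each give only a limit in this assay, not a number, so the step between them cannot be read: the limit of > 20000 nM in this assay, at which 2 of the 4 values shown sit.

The compounds shown leave open whether 2-methylprop-1-en-1-yl in place of isobutyl changes the read-out at all, on the core of compound 1 or on that of compound 2.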